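The source may hold more compounds than are shown below. What is called first, only, known or untested is meant among the compounds shown, and "the series" means these compounds.

Measured so far, all in the same cell test:

Compound 1 `CCCOC(=O)CCC(=O)N1CCN(CCCOc2cc3c(Nc4ccc(F)c(Cl)c4)ncnc3cc2OC)CC1` — 80.9%
Compound 2 `CCCCOC(=O)CCC(=O)N1CCN(CCCOc2cc3c(Nc4ccc(F)c(Cl)c4)ncnc3cc2OC)CC1` — 79.1%
Compound 3 `CCCCCCCCCCCOC(=O)CCC(=O)N1CCN(CCCOc2cc3c(Nc4ccc(F)c(Cl)c4)ncnc3cc2OC)CC1` — 12%

All three were read in a functional assay on A549 cells (Homo sapiens) for cytotoxicity, read by MTT assay, with a stated time of 24 h, tested at 40 uM; on this read-out higher numbers stand for a weaker effect at the one concentration tested and lower numbers for a stronger effect. Compound 2 differs from compound 1 by methyl in place of hydrogen on a saturated chain carbon, three bonds along the chain from an oxygen next to a carbonyl group, and that step is a number 1.8 percentage points lower from compound 1 to compound 2 (within the scatter). Compound 3 differs from compound 1 by octyl in place of hydrogen on a saturated chain carbon, three bonds along the chain from an oxygen next to a carbonyl group, a much longer chain, and that step is a number 68.9 percentage points lower from compound 1 to compound 3 (beyond the scatter); from compound 2 to compound 3 the step is a number 67.1 percentage points lower from compound 2 to compound 3 (beyond the scatter). Compound 3 is the lowest of the three in this assay, both other values standing beyond the scatter above it.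

Compound 4 `CCCCCCCCCCCCOC(=O)CCC(=O)N1CCN(CCCOc2cc3c(Nc4ccc(F)c(Cl)c4)ncnc3cc2OC)CC1` has not yet been measured. It differs from compound 3 by methyl in place of hydrogen on a saturated chain carbon, ten or more bonds along the chain from an oxygen next to a carbonyl group. This is the same kind of change as from compound 1 to compound 2, but it sits at a different place on the chain, as the two differences show. Since the earlier step was a number 1.8 percentage points lower from compound 1 to compound 2 (within the scatter) and compound 3 already gives 12%, little room for change is expected; the step from compound 3 to compound 4 is estimated at a number 2 percentage points lower from compound 3 to compound 4 (within the scatter). Compound 4 is expected to give about 10%, between 3% and 25%.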

Compound 4, a percentage reported as activity, at one concentration (the size of the read-out at that concentration, not a potency): 5.7%
For compound 4 the middle estimate is 4.3 percentage points above the measured one, within the range that was stated.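

In this assay, methyl in place of hydrogen carries over from the shorter chain to the longer one, and the new result, a number 6.3 percentage points lower from compound 3 to compound 4 (within the scatter), agrees with the earlier step: the same change on two cores in this assay, a number 1.8 percentage points lower (within the scatter) from compound 1 to compound 2 and a number 6.3 percentage points lower (within the scatter) from compound 3 to compound 4, 4.5 percentage points apart, within the scatter of two such steps The much larger chain extension also carries over, with a number 73.4 percentage points lower from compound 2 to compound 4 (beyond the scatter) and, for the nonyl change, a number 75.2 percentage points lower from compound 1 to compound 4 (beyond the scatter), and the octyl change gives matching steps on the two cores: the same change on two cores in this assay, a number 68.9 percentage points lower (beyond the scatter) from compound 1 to compound 3 and a number 73.4 percentage points lower (beyond the scatter) from compound 2 to compound 4, 4.5 percentage points apart, within the scatter of two such steps Each comparison rests on only one pair of steps, so this shows agreement among these four compounds and does not establish a rule for other chains or other cores.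

The compounds shown jump from a butyl-bearing chain in compound 2 to far longer chains in compound 3 and compound 4, so it remains open how the read-out behaves for chains of intermediate length. Also open, from the compounds shown here alone, is what an amine or a carboxylic acid in place of the chain would do in this assay.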